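The compounds below may be only part of what the source reports. "The series", "measured", "known", "first", "only" and "open" are said of these compounds alone.

Values in a functional assay on MCF7 cells (Homo sapiens) for antiproliferative activity, read by MTT assay, with a stated time of 48 h; a higher number here means a weaker inhibitor, a lower number a stronger inhibitor:
- compound 1 `Fc1ccc2[nH]c(-c3cn(-c4ccccc4)nc3-c3ccccc3)nc2c1` gives 2430 nM
- compound 2 `Brc1ccc2[nH]c(-c3cn(-c4ccccc4)nc3-c3ccccc3)nc2c1` gives 830 nM
- compound 3 `Clc1cc2nc(-c3cn(-c4ccccc4)nc3-c3ccccc3)[nH]c2cc1Cl` gives 7560 nM

Compound 2 has the lowest number of the three, and the other two lie beyond the scatter from it. Compound 4 `O=C(OCc1ccccc1)c1ccc2[nH]c(-c3cn(-c4ccccc4)nc3-c3ccccc3)nc2c1` is unmeasured and differs from compound 2 by benzyloxycarbonyl in place of bromo on an aromatic carbon in the form of benzyloxycarbonyl in place of bromo on an aromatic carbon. Among the measured compounds shown here, the only measured step at this place is a 2.9-fold lower number from compound 1 to compound 2 (0.47 log units; beyond the scatter) and involves bromo in place of fluoro, so it is a loose guide to so different a group. For the measured compounds named here, with compound 2 at 830 nM as the lowest number so far, a modest move to a higher number is expected in this assay. The estimated change is a 2.2-fold higher number from compound 2 to compound 4 (0.34 log units; beyond the scatter) and remains uncertain. For compound 4 the expected value is 1800 nM, with an estimated range from 500 nM to 6500 nM.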

Compound 4, half-maximal inhibitory concentration: 12600 nM
Compound 4: the middle estimate sits 7.0-fold (0.85 log units) below what was measured, and the stated range ends below it.
By their numbers in this assay, from the lowest: compound 2; then compound 1; then compounds 3 and 4 (each within the scatter of the next).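

Benzyloxycarbonyl is the first group at this aromatic carbon to move the number well up rather than down: replacing bromo gives a 15-fold higher number from compound 2 to compound 4 (1.18 log units; beyond the scatter), and replacing fluoro gives a 5.2-fold higher number from compound 1 to compound 4 (0.71 log units; beyond the scatter). The step from bromo is much larger than the halogen exchange alone suggested, so this position is sensitive to the group it carries. Nothing available explains the change.

Still open, as far as these compounds go, is which part of benzyloxycarbonyl drives the higher number, the carbonyl or the added aromatic ring. A carboxylic acid, a methyl ester or a primary amide here would help separate the two.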